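A few compounds are considered here, and "the series" means these few. Any claim that something is new, unique, unknown or untested is made for them only; others in the source may bear on it.

In a functional assay on A549 cells (Homo sapiens) for cytotoxicity, read by MTT assay, with a stated time of 48 h (on this read-out lower numbers stand for stronger inhibition and higher numbers for weaker inhibition), the compounds measured so far stand as follows
- compound 1 `CCCCNCCOc1c(O)cc(O)c2c(=O)cc(-c3ccccc3)oc12` gives "not determined" (no result reported) with no number to use
- compound 2 `COc1c(OCc2ncc(C)o2)cc(O)c2c(=O)cc(-c3ccccc3)oc12` gives > 100000 nM as a limit
- compound 3 `CN(C)CCCCOc1c(O)cc(O)c2c(=O)cc(-c3ccccc3)oc12` gives > 100000 nM as a limit

Compound 2 reads > 100000 nM which is a limit of the assay and not a number. Compound 3 reads > 100000 nM which is also a limit. Going by the values given here, the series so far offers the limit of > 100000 nM in this assay, at which 2 of the 3 values shown sit, and no measured step between compounds.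

The next compound is compound 4 `CCN(CC)CCCCOc1cc(O)c2c(=O)cc(-c3ccccc3)oc2c1OC` and its change from compound 2 is 3-(diethylamino)propyl in place of 5-methyl-1,3-oxazol-2-yl on a saturated chain carbon bound to an oxygen on an aromatic ring in the ether side chain. Cut one bond further out, this reads (5-methyl-1,3-oxazol-2-yl)methoxy to 4-(diethylamino)butoxy.

Among the compounds with values here, with the limit of > 100000 nM in this assay, at which 2 of the 3 values shown sit, as the only guide, a small move toward stronger inhibition is expected in this assay and it may not exceed the scatter. The estimated change is an at least 1.4-fold lower number from compound 2 to compound 4 (0.15 log units; that floor lies within the scatter) and another reading at the limit remains quite possible. For compound 4 the expected value is 70000 nM with an estimated range from 20000 nM to 150000 nM in this read-out.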

Compound 4, half-maximal inhibitory concentration: 1000 nM
Estimate against measurement, compound 4: 70-fold (1.85 log units) above, outside the stated range (below it).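

In this assay, replacing (5-methyl-1,3-oxazol-2-yl)methoxy with 4-(diethylamino)butoxy in the ether side chain gives an at least 100-fold lower number from compound 2 to compound 4 (2.00 log units; beyond the scatter) on an otherwise unchanged core. Compound 4 is the first compound here to give a number and not a limit, so this position is now shown to respond to a change of group. The step gives only a minimum size, since compound 2 reads at a limit of the assay: the limit of > 100000 nM in this assay, at which 2 of the 4 values shown sit.

Compound 3 differs from compound 4 in more than one place, so it does not separate the effect of the diethylamino end from that of the methoxy group on the core. From the compounds shown here alone, whether the amine itself is needed remains open: a plain butoxy chain or a 4-(morpholin-4-yl)butoxy chain on the core of compound 4 would bear on this.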